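This account rests on a few compounds, and the source may have more. Where it says the series, first, only, none or still open, it means among the compounds named here.

Compound 1 `O=C(NNc1cccc(Cl)c1)c1ccc(NS(=O)(=O)c2cnc(O)nc2O)cc1`: 11600 nM
Compound 2 `O=C(NNc1ccccc1F)c1ccc(NS(=O)(=O)c2cnc(O)nc2O)cc1`: 16000 nM
Compound 3 `O=C(NNc1cccc(Cl)c1)c1ccccc1NS(=O)(=O)c1cnc(O)nc1O`: 10800 nM

In a functional assay on SGC-7901 cells (Homo sapiens) for antiproliferative activity, read by MTT assay, with a stated time of 24 h (a lower number here means a stronger inhibitor, a higher number a weaker inhibitor), compound 1 gives 11600 nM and compound 2 gives 16000 nM; the change 2-fluorophenyl in place of 3-chlorophenyl on an amine nitrogen makes a 1.4-fold higher number from compound 1 to compound 2 (0.14 log units; within the scatter). Compound 3 has the same atoms as compound 1 joined differently, and the difference between the two cores is not broken down here. In this assay compound 3 gives 10800 nM, within the scatter of both compound 1 and compound 2. Compound 4 `O=C(NNc1ccccc1F)c1ccccc1NS(=O)(=O)c1cnc(O)nc1O` is not yet measured in this assay; it differs from compound 3 by 2-fluorophenyl in place of 3-chlorophenyl on an amine nitrogen, the same change as between compound 1 and compound 2, made at the same place. The step from compound 3 to compound 4 is expected to be about a 1.4-fold higher number from compound 3 to compound 4 (0.14 log units; within the scatter), resting on a 1.4-fold higher number from compound 1 to compound 2 (0.14 log units; within the scatter). Compound 4 is estimated at 15000 nM, expected between 8000 nM and 30000 nM.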

Compound 4, half-maximal inhibitory concentration: > 20000 nM
Compound 4: only a limit was reported; the forecaster's own chance of this, stated with the estimate: 5%; middle value at least 1.3-fold (0.12 log units) away from the limit.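

In this assay compound 4 gives > 20000 nM, which is a limit of the assay and not a number. On this core, 2-fluorophenyl in place of 3-chlorophenyl gives an at least 1.8-fold higher number from compound 3 to compound 4 (0.26 log units; that floor lies within the scatter), so the result fits the change carrying over from the core of compound 1 but does not establish that it does. The size of the step on this core stays unknown, and equal and different effects on the two cores both remain possible: the same change on two cores in this assay, a 1.4-fold higher number (0.14 log units; within the scatter) from compound 1 to compound 2 and an at least 1.8-fold higher number (0.26 log units; that floor lies within the scatter) from compound 3 to compound 4; the limit leaves it open whether they differ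

The compounds shown compare only 3-chlorophenyl and 2-fluorophenyl on the amine nitrogen. Open, from the compounds shown here alone, is how either core responds to an unsubstituted phenyl, a methoxyphenyl or a carboxylic acid-bearing phenyl there, and whether any such group moves the number beyond the scatter.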